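Swapping the acyl arm of compound 2 for a pyridine

This account rests on a few compounds, and the source may have more. Where it says the series, first, only, none or still open, it means among the compounds named here.

Two compounds of this series have been examined in an ADME assay on HEK-293T cells (Homo sapiens) for cytotoxicity, read by MTT assay, with a stated time of 24 h; on this read-out higher numbers stand for lower toxicity in this test and lower numbers for higher toxicity in this test. Compound 1 `O=C(c1ccncc1)n1c(-c2cn(-c3ccccc3)nc2-c2ccc(C(F)(F)F)cc2)nc2ccccc21` gives 135000 nM in this assay. Compound 2 `Cc1ccc(C(=O)n2c(-c3cn(-c4ccccc4)nc3-c3ccc(C)cc3)nc3ccccc32)cc1` gives 176000 nM in this assay, the higher of the two numbers, with compound 1 only a short distance away, well within the scatter, so the two cannot be set in order.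

Compound 3 `Cc1ccc(-c2nn(-c3ccccc3)cc2-c2nc3ccccc3n2C(=O)c2ccncc2)cc1` has not been measured in this assay. It differs from compound 2 in a single spot: pyridin-4-yl in place of 4-methylphenyl on a carbonyl carbon. Compound 1 already carries the pyridin-4-yl carbonyl, and its number lies within the scatter of compound 2, so this change is not expected to move the read-out beyond the scatter in either direction. Compound 3 is therefore estimated at 150000 nM in this assay, with a range of 75000 nM to 300000 nM. The expected step from compound 2 is a 1.2-fold lower number from compound 2 to compound 3 (0.07 log units; within the scatter).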

Compound 3, half-maximal cytotoxic concentration: 154000 nM
Beside the measured number, compound 3's estimate is 1.0-fold (0.01 log units) below it; the range from low to high includes it.
By their numbers in this assay, from the lowest: compounds 1, 3 and 2 (each within the scatter of the next).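

In this assay the step of pyridin-4-yl in place of 4-methylphenyl on a carbonyl carbon gives a 1.1-fold lower number from compound 2 to compound 3 (0.06 log units; within the scatter), a direct reading of this swap at this position with the rest of the molecule held fixed. With the pyridin-4-yl carbonyl kept in place, methyl in place of trifluoromethyl on an aromatic carbon gives a 1.1-fold higher number from compound 1 to compound 3 (0.06 log units; within the scatter), so neither single change is seen to move the read-out beyond the scatter. Nothing available here bears on why these numbers stay so close.

The compounds shown leave open whether a carboxylic acid or an amine on the acyl ring would shift the number beyond the scatter. They also leave open whether a longer alkyl chain on the carbonyl carbon, in place of the ring, would do so.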